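Taking the acetyl group off compound 1

The source may hold more compounds than are shown below. What is called first, only, known or untested is meant among the compounds shown, and "the series" means these compounds.

Measured so far:
Compound 1 `CC(=O)Nc1ccc2oc(-c3ccccc3F)cc(=O)c2c1`: > 125000 nM
Compound 2 `CC(=O)Nc1ccc2oc(-c3cccc(F)c3)cc(=O)c2c1`: > 125000 nM

In an ADME assay on THP-1 cells (Homo sapiens) for cytotoxicity, read by flow cytometry and propidium iodide staining, with a stated time of 72 h (a higher number here means a weaker inhibitor, a lower number a stronger inhibitor), compound 1 gives > 125000 nM, which is a limit and not a number. Compound 2 gives > 125000 nM, which is also a limit. All that is known so far is therefore (the limit of > 125000 nM in this assay, at which 2 of the 2 values shown sit).

Compound 3 `Nc1ccc2oc(-c3ccccc3F)cc(=O)c2c1` has not yet been measured. It differs from compound 1 by hydrogen in place of acetyl on a nitrogen on an aromatic ring, or acetamido to amino: hydrogen in place of acetyl on a nitrogen on an aromatic ring.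

Going by the values given here, only one measured step exists, a step that the two limits leave unreadable from compound 1 to compound 2. It concerns the fluorophenyl group rather than the acetamido group, and its size cannot be read, so it offers no size to carry over. Neither measured compound carries the amino group.

Given compound 1 at the limit of > 125000 nM in this assay, at which 2 of the 2 values shown sit, any readable change in this assay is expected to point towards a lower number, meaning a stronger effect, though compound 3 may well stay at a limit too. The expected change is an at least 1.2-fold lower number from compound 1 to compound 3 (0.09 log units; that floor lies within the scatter), and this is only an estimate. The estimate for compound 3 is 100000 nM. The expected range for that estimate runs from 25000 nM to 250000 nM.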

Compound 3, half-maximal inhibitory concentration: 44000 nM
Beside the measured number, compound 3's estimate is 2.3-fold (0.36 log units) above it; low and high end bracket the measured number.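

Going by these compounds alone, the acetamido group is the first place where a change produces a readable effect in this assay. Hydrogen in place of acetyl on a nitrogen on an aromatic ring gives an at least 2.8-fold lower number from compound 1 to compound 3 (0.45 log units; beyond the scatter), so removing the acetyl lets the cell-killing effect appear within the range this assay can read, though it remains weak in absolute terms at 44000 nM for compound 3. Within the data shown here, the true size of the step may be larger, since its starting point is only a limit and the earlier fluorophenyl step cannot be read, and compound 3 is the only compound here with a real number, the others sitting at a limit: the limit of > 125000 nM in this assay, at which 2 of the 3 values shown sit.

The compounds shown leave open whether the free amino group itself matters or whether losing the acetyl is enough, which a methylamino group, a hydroxyl group or a longer acyl chain such as propionyl at this place could begin to separate. From the compounds shown here alone, it also remains open whether the same change would give a similar step with the 3-fluorophenyl group of compound 2.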